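Cyclohexylmethyl to trifluoromethylbenzyl: what the liver cells may say

The source may hold more compounds than are shown below. What is called first, only, known or untested is meant among the compounds shown, and "the series" means these compounds.

Of the compounds shown here, three of one series have been measured in an ADME assay on HepG2 cells (Homo sapiens) for cytotoxicity, read by luminescence, CellTiter-Glo and ATP content, with a stated time of 72 h; on this read-out lower numbers stand for an effect already at smaller amounts and higher numbers for an effect only at larger amounts of compound. Compound 1 `COc1ccc(Oc2ccc3c(NCCCNCc4cccc(OC)c4O)ccnc3c2)cc1` gives 5500 nM, compound 2 `COc1cccc(CNCCCNc2ccnc3cc(-c4ccc(F)cc4)ccc23)c1O` gives 6840 nM, and compound 3 `COc1cccc(CNCCCNc2ccnc3cc(CC4CCCCC4)ccc23)c1O` gives 970 nM. Compound 3 stands lowest of the three: the nearest value is that of compound 1, which lies above it by a 5.7-fold lower number from compound 1 to compound 3 (0.75 log units; beyond the scatter) read backwards, and compound 2 lies further still, by a 7.1-fold lower number from compound 2 to compound 3 (0.85 log units; beyond the scatter) in the opposite sense. Between compound 1 and compound 2 the difference is a 1.2-fold higher number from compound 1 to compound 2 (0.09 log units; within the scatter).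

Compound 4 `COc1cccc(CNCCCNc2ccnc3cc(Cc4cccc(C(F)(F)F)c4)ccc23)c1O` is not yet measured. It differs from compound 3 in one place: 3-(trifluoromethyl)phenyl in place of cyclohexyl on a saturated chain carbon bound to an aromatic carbon. Within the data shown here, the steps that bear on this are those from compound 1 to compound 3 and from compound 2 to compound 3, both of which replaced an aromatic group by cyclohexylmethyl and both of which lowered the number in this assay well beyond the scatter. Compound 4 goes the other way, putting an aromatic ring back on the chain, so the number is expected to rise, though the benzyl link makes the parallel loose and the expected step is kept modest at a 2.6-fold higher number from compound 3 to compound 4 (0.41 log units; beyond the scatter). For compound 4 the estimated value in this assay is 2500 nM, with a range from 900 nM to 7000 nM.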

Compound 4, half-maximal effective concentration: 1720 nM
Estimate against measurement, compound 4: 1.5-fold (0.16 log units) above; measured number inside the range.
By their numbers in this assay, from the lowest: compounds 3 and 4 (each within the scatter of the next); then compounds 1 and 2 (each within the scatter of the next).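

In this assay, 3-(trifluoromethyl)phenyl in place of cyclohexyl on a saturated chain carbon bound to an aromatic carbon gives a 1.8-fold higher number from compound 3 to compound 4 (0.25 log units; within the scatter) and so cannot be told apart from cyclohexyl on this read-out, which shows that an aromatic ring on that chain carbon does not by itself bring the number back to the level of compounds 1 and 2. Compound 4 stays clearly separate from those two, with a 4.0-fold lower number from compound 2 to compound 4 (0.60 log units; beyond the scatter) and a 3.2-fold lower number from compound 1 to compound 4 (0.50 log units; beyond the scatter), so among these four compounds the two groups attached through a saturated chain carbon give lower numbers than 4-fluorophenyl and 4-methoxyphenoxy, and no compound shown goes against this. Nothing available gives a reason for these steps.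

The compounds shown leave open whether the trifluoromethyl group plays any part, which a plain benzyl group would address, and what a longer chain such as cyclohexylethyl or a ring carrying an amine would give at this place. They also leave open whether the saturated chain carbon alone sets the level, since compounds 1 and 2 differ from compound 4 in the whole group.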